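The source may report more compounds than this note shows. Statements on the series, on what has been measured and on what is new or still open speak of the compounds shown alone.

Measured so far in a functional assay (thoracic aorta) for inhibition, with Rattus norvegicus as the target; on this read-out lower numbers stand for stronger inhibition and higher numbers for weaker inhibition:
- compound 1 `O=C(O)c1cc(CCCCNS(=O)(=O)c2ccccc2)c2cccccc1-2`: 570 nM
- compound 2 `O=C(O)c1cc(CCCCCCCNS(=O)(=O)c2ccccc2)c2cccccc1-2`: 18 nM
- compound 3 `CC(C)c1ccc2c(CCCCNS(=O)(=O)c3ccccc3)cc(C(=O)O)c-2cc1`: 70 nM

Compound 3, at 70 nM, holds the middle place of the three numbers, with compound 2 lower and compound 1 higher, and both gaps lie beyond the scatter.

Compound 4 `CC(C)c1ccc2c(CCCCNS(=O)(=O)c3ccc(Cl)cc3)cc(C(=O)O)c-2cc1` keeps all of compound 3 except the phenylsulfonyl group, which becomes (4-chlorophenyl)sulfonyl: chloro in place of hydrogen on an aromatic carbon. Within the data shown here, the only measured step between compounds that differ in one place is an 8.1-fold lower number from compound 1 to compound 3 (0.91 log units; beyond the scatter), a modest change with isopropyl in place of hydrogen on an aromatic carbon. It lies elsewhere in the molecule, so it bears on this change only loosely. Among the measured compounds shown here, no measured compound carries a substituent on the phenyl ring of the sulfonyl group, and the data therefore fix no direction. A small step towards a lower number is expected in this assay, and it may stay within the scatter. This estimate amounts to an expected 2.0-fold lower number from compound 3 to compound 4 (0.30 log units; within the scatter). Compound 4 is estimated at 35 nM, with an expected range from 10 nM to 110 nM.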

Compound 4, half-maximal inhibitory concentration: 5.3 nM
Estimate against measurement, compound 4: 6.6-fold (0.82 log units) above; the whole stated range lies above it.
By their numbers in this assay, from the lowest: compound 4; then compound 2; then compound 3; then compound 1.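

Among these compounds, with the sulfonyl phenyl ring now substituted for the first time, chloro on this aromatic carbon, para to a large group, gives a large step in this assay, a 13-fold lower number from compound 3 to compound 4 (1.12 log units; beyond the scatter), well beyond the scatter. The earlier compounds shown here showed change only at the isopropyl place, an 8.1-fold lower number from compound 1 to compound 3 (0.91 log units; beyond the scatter), so this result adds a second place in the molecule where a single substituent lowers the number. No measurement shown here accounts for the step.

The compounds shown leave open whether fluoro, bromo, methyl or methoxy at the same place would give a similar step, or whether another position on that ring would serve as well. They also leave open whether chloro would lower the number to a similar extent on compound 1, which lacks isopropyl, or on compound 2, with its longer chain.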